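This account rests on a few compounds, and the source may have more. Where it says the series, first, only, none or still open, it means among the compounds named here.

Measured in a functional assay on HeLa cells (Homo sapiens) for inhibition, read by CCK-8 assay, with a stated time of 48 h; on this read-out lower numbers stand for stronger inhibition and higher numbers for weaker inhibition:
- Compound 1 `COc1cc(-c2ccnc3cc(-c4ccc(C)cc4)nn23)cc(OC)c1OC`: 21 nM
- Compound 2 `COc1cc(-c2ccnc3cc(-c4cccc(C#N)c4)nn23)cc(OC)c1OC`: > 10000 nM (a limit of the assay)
- Compound 3 `COc1cc(-c2ccnc3cc(-c4ccc5c(ccn5C)c4)nn23)cc(OC)c1OC`: 19 nM

Compound 3 stands level with compound 1, with a 1.1-fold lower number from compound 1 to compound 3 (0.04 log units; within the scatter). Compound 2 lies far off, with an at least 520-fold lower number from compound 2 to compound 3 (2.72 log units; beyond the scatter).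

Next is compound 4 `COc1cc(-c2ccnc3cc(-c4ccc(C(F)(F)F)cc4)nn23)cc(OC)c1OC`, with this change: 4-(trifluoromethyl)phenyl in place of 1-methyl-1H-indol-5-yl on an aromatic carbon. Swaps on this same aromatic carbon have gone both ways. In compound 3 the swap cost nothing, with a 1.1-fold lower number from compound 1 to compound 3 (0.04 log units; within the scatter), whereas compound 2 shows an at least 470-fold higher number from compound 1 to compound 2 (2.67 log units; beyond the scatter). Compound 4 carries a 4-substituted phenyl like compound 1, so a moderate rise in this assay is expected rather than a collapse. The expected step is a 7.9-fold higher number from compound 3 to compound 4 (0.90 log units; beyond the scatter). For compound 4 the estimated value is 150 nM, with an expected range from 20 nM to 3000 nM.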

Compound 4, half-maximal inhibitory concentration: 1840 nM
Compound 4: the middle estimate sits 12-fold (1.09 log units) below what was measured; measured number inside the range.
By their numbers in this assay, from the lowest: compounds 3 and 1 (each within the scatter of the next); then compound 4. At a limit, above all of these: compound 2.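

In this assay, with the phenyl ring kept, trifluoromethyl in place of methyl gives an 88-fold higher number from compound 1 to compound 4 (1.94 log units; beyond the scatter), so the substituent on that ring alone can move the number a long way. The step of a 97-fold higher number from compound 3 to compound 4 (1.99 log units; beyond the scatter) shows that this aromatic carbon also allows an intermediate level, not only the level near compound 1 or a reading at a limit. The step of an at least 5.4-fold lower number from compound 2 to compound 4 (0.73 log units; beyond the scatter) is only a bound, resting on a limit: the limit of > 10000 nM in this assay, at which 1 of the 4 values shown sits.

Open, on these data alone, is how a methoxy group or an amine in place of methyl would read, and whether the nitrile itself or its place on the ring governs compound 2.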